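From dimethylamino to trifluoromethoxy: a cytotoxicity estimate

A few compounds are considered here, and "the series" means these few. Any claim that something is new, unique, unknown or untested is made for them only; others in the source may bear on it.

Of the compounds shown here, two have been tested so far in a toxicity assay on MDCK cells (Canis lupus familiaris) for cytotoxicity, read by crystal violet staining, with a stated time of 48 h; a lower number here means that less compound is tolerated, a higher number that more compound is tolerated. Compound 1 (`CC(C)c1ccc2[nH]c(=O)c(CN(Cc3ccc(C(C)(C)C)cc3)C(C)c3ccc(N(C)C)c(Cl)c3)cc2c1`) gives > 10000 nM, which is a limit of the assay and not a number. For the measured compounds named here, compound 2 (`CC(c1ccc(N(C)C)c(Cl)c1)N(Cc1ccc(C(C)(C)C)cc1)Cc1cc2cc(Br)ccc2[nH]c1=O`) gives 6100 nM, the only true number available, so it cannot yet be ranked within a series.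

The two compounds differ by bromo in place of isopropyl on an aromatic carbon, and that exchange gives an at least 1.6-fold lower number from compound 1 to compound 2 (0.21 log units; that floor lies within the scatter). Going by the values given here, this is the only measured step, and it concerns a different group from the one that changes next, so it offers little guidance.

Compound 3 (`CC(c1ccc(OC(F)(F)F)c(Cl)c1)N(Cc1ccc(C(C)(C)C)cc1)Cc1cc2cc(Br)ccc2[nH]c1=O`) keeps the bromo but carries trifluoromethoxy in place of dimethylamino on an aromatic carbon, ortho to a chloro group: trifluoromethoxy in place of dimethylamino on an aromatic carbon. Among the compounds with values here, no measured step involves this exchange, so the starting point is simply compound 2 at 6100 nM, and no step beyond the scatter is expected in this assay.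

The expected step is a 1.0-fold lower number from compound 2 to compound 3 (0.01 log units; within the scatter). For compound 3 the estimated value is 6000 nM, with an expected range from 2500 nM to 10000 nM.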

Compound 3, half-maximal cytotoxic concentration: > 10000 nM
Compound 3: no number, only a limit; the forecaster's own chance of this, stated with the estimate: 25%; middle value at least 1.6-fold (0.22 log units) from the limit.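

Moving from dimethylamino to trifluoromethoxy on an aromatic carbon, ortho to a chloro group and para to a large group, gives an at least 1.6-fold higher number from compound 2 to compound 3 (0.21 log units; that floor lies within the scatter) in this assay. The value of compound 3 is a limit of the assay and not a number, so the step may be larger than this floor, which itself lies within the scatter. This is the first measured change at this place, and it shows that dimethylamino can give way to trifluoromethoxy without any sign that less compound is tolerated, while the real gap between the two groups stays unknown: the limit of > 10000 nM in this assay, at which 2 of the 3 values shown sit.

Still open, on these data alone, is whether another group at this place, such as methoxy or the ring amine morpholine, would give a true number in this assay rather than a limit. As far as these compounds go, it is also open whether trifluoromethoxy would leave the same picture with isopropyl in place of the bromo, or with a different group, such as a nitrile, on that part of the shared core.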